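Notes on a cinnamate ester series: replacing the biaryl tail

This account rests on a few compounds, and the source may have more. Where it says the series, first, only, none or still open, it means among the compounds named here.

Measured so far:
- compound 1 `COC(=O)/C=C/c1cccc(N(Cc2ccc(-c3ccc(F)c(F)c3)cc2)C(=O)C2CCCCC2)c1`: 72 nM
- compound 2 `COC(=O)/C=C/c1cccc(N(Cc2ccc(-c3c(OC)cccc3OC)cc2)C(=O)C2CCCCC2)c1`: 77 nM
- compound 3 `COC(=O)/C=C/c1cccc(N(Cc2ccc(-c3c(OC)cccc3OC)cc2)C(=O)C(C)C)c1`: 95 nM

In an assay on isolated protein with Bile acid receptor (Homo sapiens) as the target (a lower number here means that less compound is needed, a higher number that more compound is needed for the effect), compound 2 gives 77 nM. The three numbers sit close together: a 1.1-fold higher number from compound 1 to compound 2 (0.03 log units; within the scatter) and a 1.2-fold higher number from compound 2 to compound 3 (0.09 log units; within the scatter) are both within the scatter, so compound 2 cannot be set apart from compound 1 or compound 3 on these data.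

Compound 4 `COC(=O)/C=C/c1cccc(N(Cc2ccc(/C=C/C(=O)OCc3ccccc3)cc2)C(=O)C2CCCCC2)c1` is not yet measured. It differs from compound 2 in one place: 2-(benzyloxycarbonyl)ethenyl in place of 2,6-dimethoxyphenyl on an aromatic carbon.

Going by the values given here, only the step from compound 1 to compound 2 touches the same place, and it was a 1.1-fold higher number from compound 1 to compound 2 (0.03 log units; within the scatter), with a different six-membered aromatic ring swapped in. The step from compound 2 to compound 3 concerns the acyl group and does not bear on the tail. Among the compounds with values here, there is no measured pair that exchanges an aryl ring for an ester-bearing ethenyl chain at this place, so the expectation rests on the tolerance seen in compound 1 and compound 2. A modest rise in the number, if any, is expected: a 1.4-fold higher number from compound 2 to compound 4 (0.15 log units; within the scatter). Compound 4 is therefore estimated at 110 nM in this assay, with a range from 40 nM to 350 nM.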

Compound 4, half-maximal effective concentration: > 1000 nM
Compound 4: a limit, no number (the forecaster's own chance of this, stated with the estimate: 5%); middle value at least 9.0-fold (0.95 log units) away from the limit.
By their numbers in this assay, from the lowest: compounds 1, 2 and 3 (each within the scatter of the next). At a limit, above all of these: compound 4.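

The tail position does not accept every group of similar size. 3,4-Difluorophenyl and 2,6-dimethoxyphenyl sit within the scatter of each other, whereas 2-(benzyloxycarbonyl)ethenyl gives an at least 12-fold higher number from compound 2 to compound 4 (1.11 log units; beyond the scatter) and an at least 13-fold higher number from compound 1 to compound 4 (1.14 log units; beyond the scatter). Compound 4 gives no number in this assay, only a limit of the assay: the limit of > 1000 nM in this assay, at which 1 of the 4 values shown sits. The entering group matches 2,6-dimethoxyphenyl in hydrogen-bond acceptors and donors, in net charge and in having one six-membered aromatic ring of carbon only, so these counts do not separate the tails of compound 2 and compound 4.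

The compounds shown do not tell which part of the new group goes with the step: the ethenyl link, the ester or the benzyl end. Nor do they show how a carboxylic acid or a simple amide at the end of the ethenyl chain would read in this assay.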